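A few compounds are considered here, and "the series" means these few. Any claim that something is new, unique, unknown or untested is made for them only; others in the source may bear on it.

Compound 1 `COc1cc(C)c(S(=O)(=O)N(C)CCOCC(=O)N2CCN(CCN(C)C)CC2)c(C)c1` and compound 2 `COc1cc(C)c(S(=O)(=O)N(C)CCOCC(=O)N2CCN([C@@H]3CN4CCC3CC4)CC2)c(C)c1` share one core and differ only in the group attached to an amine nitrogen in a ring. In an assay on HEK293 cells for displacement of a labelled ligand from B1 bradykinin receptor (Homo sapiens), read by scintillation counting (on this read-out lower numbers stand for stronger inhibition and higher numbers for weaker inhibition), compound 1 gives 106 nM, and compound 2 gives 5.6 nM, which is the lowest of the two numbers. That change produced a 19-fold lower number from compound 1 to compound 2 (1.28 log units; beyond the scatter), so replacing a chain by two fused rings on that nitrogen mattered a great deal here.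

Compound 3 `COc1cc(C)c(S(=O)(=O)N(C)CCOCC(=O)N2CCN(CC3CCN(C)CC3)CC2)c(C)c1` takes the next step from compound 2: a group of 8 heavy atoms (7 carbon, 1 nitrogen; one six-membered non-aromatic ring with 1 hetero atom) in place of a group of 8 heavy atoms (7 carbon, 1 nitrogen; 2 six-membered non-aromatic rings with 1 hetero atom each), on an amine nitrogen in a ring. The (1-methylpiperidin-4-yl)methyl group keeps one ring and the nitrogen but gives up the second ring, placing it part way between the chain of compound 1 and the two-ring group of compound 2. For the measured compounds named here, only the step from compound 1 to compound 2 bears on this, and it was large. On that basis the number in this assay for compound 3 is expected to rise, by about a 3.6-fold higher number from compound 2 to compound 3 (0.55 log units; beyond the scatter). Compound 3 is therefore estimated at 20 nM, with a range from 5 nM to 80 nM.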

Compound 3, inhibition constant: 4.5 nM
Compound 3: the middle estimate sits 4.4-fold (0.65 log units) above what was measured; measured number below the stated range.
By their numbers in this assay, from the lowest: compounds 3 and 2 (each within the scatter of the next); then compound 1.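

In this assay the second ring of compound 2 turns out not to be required: the (1-methylpiperidin-4-yl)methyl group of compound 3 gives a 1.2-fold lower number from compound 2 to compound 3 (0.09 log units; within the scatter) and so stands level with the two-ring group. The advantage over the open chain of compound 1 remains, with a 24-fold lower number from compound 1 to compound 3 (1.37 log units; beyond the scatter) and thus a large step, so in these three compounds a single six-membered ring carrying the nitrogen is enough to match what two rings give. Nothing available explains why the two ring groups match.

From the compounds shown here alone, whether the nitrogen in that ring matters remains open, as a cyclohexylmethyl group would test that by putting a carbon in its place. Going by these compounds, it is also open what a 1-methylpiperidin-4-yl group would give when attached directly, without its methylene link.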